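This account rests on a few compounds, and the source may have more. Where it says the series, first, only, none or still open, it means among the compounds named here.

Compound 1, with the structure `c1ccc(Nc2ccc(N3CC4CC(C3)N4)nn2)cc1`, was tested in an assay on cell membranes for displacement of a labelled ligand from Neuronal acetylcholine receptor; alpha4/beta2 (Rattus norvegicus) (on this read-out lower numbers stand for stronger inhibition and higher numbers for weaker inhibition), where it gives 441 nM. Among the three compounds measured, this is the highest number, which means the weakest binding. The other two share the bicyclic amine and the aryl-amino arm but sit on a different core. Compound 2, `O=[N+]([O-])c1ccc(Nc2cncc(N3CC4CC(C3)N4)c2)cc1`, carries a nitro group on its outer ring and gives 0.0225 nM in this assay, a far lower number than compound 1, well beyond the usual scatter. Compound 3, `Clc1cccc(Nc2ccc(N3CC4CC(C3)N4)cn2)c1`, carries a chlorine on its outer ring and gives 2.2 nM in this assay, again a clearly lower number than compound 1.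

Compound 4, `Cc1ccc(Nc2ccc(N3CC4CC(C3)N4)nn2)cc1`, has not yet been measured. It keeps the core of compound 1 and differs from it in one place: methyl in place of hydrogen on an aromatic carbon. Within the data shown here, no pair of measured compounds shows this same change, so its effect has to be guessed from the single anchor that compound 1 provides. A small change of this kind is expected to move the number only modestly, if at all, and the step from compound 1 to compound 4 is estimated at a 1.8-fold lower number from compound 1 to compound 4 (0.25 log units; within the scatter). Compound 4 is therefore expected to give about 250 nM in this assay, within a range from 60 nM to 1000 nM.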

Compound 4, inhibition constant: 44.3 nM
Estimate against measurement, compound 4: 5.6-fold (0.75 log units) above; the whole stated range lies above it.
By their numbers in this assay, from the lowest: compound 2; then compound 3; then compound 4; then compound 1.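

The outer ring of compound 1 is not a silent part of the molecule: in this assay, going from phenyl to 4-methylphenyl gives a 10-fold lower number from compound 1 to compound 4 (1.00 log units; beyond the scatter) and this step lies beyond the usual scatter. This place on a six-membered aromatic ring of carbon only, para to a large group, therefore responds clearly to the addition of a single carbon atom, something the three earlier compounds could not show because no two of them differed in just one place. Nothing shown here gives a cause for this step, so it stands as an observation only.

On these data alone, it remains open whether the number would keep falling with an ethyl or methoxy group at this same place, or would move the other way with an amine or a carboxylic acid. Also unresolved is what chlorine or a nitro group would do on the core of compound 1, and whether methyl would have a similar effect on the cores of compound 2 and compound 3.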